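The source may hold more compounds than are shown below. What is called first, only, known or untested is meant among the compounds shown, and "the series" means these compounds.

For the measured compounds named here, compound 2 `Cc1cccc(NC(=O)C(=O)Nc2ccc(OCC(=O)O)c(F)c2)c1` gives 36.3% in a functional assay on CHO cells for agonist activity at Free fatty acid receptor 1 (Homo sapiens), read by FLIPR, tested at 300 nM (on this read-out lower numbers stand for a weaker effect and higher numbers for a stronger effect at the one concentration tested), the higher of the two numbers known, while compound 1 `Cc1ccc(NC(=O)C(=O)Nc2ccc(OCC(=O)O)c(F)c2)cc1` gives 29.9%. Going by the values given here, the one measured step, a number 6.4 percentage points higher from compound 1 to compound 2 (within the scatter), moves a methyl around the ring without leaving the scatter. Compound 3 `O=C(O)COc1ccc(NC(=O)C(=O)Nc2ccccc2Cl)cc1F` carries 2-chlorophenyl in place of 3-methylphenyl on an amide-type nitrogen. Among the compounds with values here, no measured step exchanges a methyl for a chlorine, and the only step known stayed within the scatter, so no change beyond the scatter is expected. Compound 3 is therefore expected to give 33%, with a range from 15% to 52%. The expected step is a number 3.3 percentage points lower from compound 2 to compound 3 (within the scatter).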

Compound 3, a percentage reported as activity, at one concentration (the size of the read-out at that concentration, not a potency): 27.9%
The estimate for compound 3 lay 5.1 percentage points above the measured number, within the range that was stated.
By their numbers in this assay, from the lowest: compounds 3, 1 and 2 (each within the scatter of the next).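

With 2-chlorophenyl on the amide-type nitrogen, the reading in this assay stays within the scatter of both methylphenyl compounds (a number 8.4 percentage points lower from compound 2 to compound 3 (within the scatter); a number 2 percentage points lower from compound 1 to compound 3 (within the scatter)). The earlier pair showed only a methyl moved around the ring, whereas this change puts a chlorine-bearing ring in place of a methyl-bearing one, and the three compounds still cannot be told apart. No measured evidence bears on this result. On these data alone, it remains open whether an amine or a carboxylic acid on this ring would give a step beyond the scatter. A longer chain in place of the ring is equally untested by the compounds shown.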